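A few compounds are considered here, and "the series" means these few. Any claim that something is new, unique, unknown or untested is made for them only; others in the source may bear on it.

Measured in a functional assay on MDA-MB-231 cells (Homo sapiens) for cytotoxicity, read by MTT assay, with a stated time of 72 h, tested at 1 uM, in the absence of a further agent; on this read-out lower numbers stand for a stronger effect and higher numbers for a weaker effect at the one concentration tested:
- compound 1, `CC1(C)CC(=O)Nc2ccc(Cl)cc21`: 82.3%
- compound 2, `CNC1=Nc2ccc(Cl)cc2C(C)(C)C1`: 91.9%
- compound 3, `CCNC1=Nc2ccc(Cl)cc2C(C)(C)C1`: 89.7%

Compound 3 sits between the numbers of compound 1 and compound 2, and its gaps to both are within the usual scatter, so none of the three measured compounds can be set apart from the others on this read-out. Among the measured compounds shown here, the only step between two compounds that differ in one place is a number 2.2 percentage points lower from compound 2 to compound 3 (within the scatter), a chain extension at the amine nitrogen that left the read-out unchanged beyond the scatter.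

The next compound, compound 4 (`CC1(C)CC(NCCCCO)=Nc2ccc(Cl)cc21`), is not yet measured. It differs from compound 3 by 2-hydroxyethyl in place of hydrogen on a saturated chain carbon, two bonds along the chain from an amine nitrogen, that is, the ethylamino chain of compound 3 grows into a (4-hydroxybutyl)amino chain. For the measured compounds named here, the one step that bears on this is a number 2.2 percentage points lower from compound 2 to compound 3 (within the scatter), also a lengthening of the chain on the amine nitrogen, and it was within the scatter. Going by the values given here, the present change is larger and adds a hydrogen-bond donor and acceptor, for which no measured step exists, so the expectation rests on that single precedent alone.

On this basis the expected step is a number 1.7 percentage points lower from compound 3 to compound 4 (within the scatter), which is not expected to exceed the scatter. Compound 4 is therefore estimated at 88%, with a range from 72% to 100%.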

Compound 4, a percentage reported as activity, at one concentration (the size of the read-out at that concentration, not a potency): 87.6%
Estimate against measurement, compound 4: 0.4 percentage points above, within the range that was stated.
By their numbers in this assay, from the lowest: compounds 1, 4, 3 and 2 (each within the scatter of the next).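

In this assay the change from ethylamino to (4-hydroxybutyl)amino gives a number 2.1 percentage points lower from compound 3 to compound 4 (within the scatter) and counts as a far larger change on the amine nitrogen than the earlier one, while 3-hydroxypropyl in place of hydrogen on the saturated chain carbon bound to the amine nitrogen gives a number 4.3 percentage points lower from compound 2 to compound 4 (within the scatter) on the same read-out. The earlier step covered only a methyl in place of hydrogen, whereas these two show that a 2-hydroxyethyl or 3-hydroxypropyl extension, with its hydrogen-bond donor and acceptor, also leaves the number within the scatter in this series. No measurement at hand offers an explanation for this result.

All steps among compound 2, compound 3 and compound 4 stay within the scatter at the single concentration tested, so the compounds shown do not tell whether any chain at this place can produce a stronger effect. Still open, going by these compounds, is whether a longer chain, or a chain carrying an amine or a carboxylic acid in place of the hydroxy group, would give a step beyond the scatter.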